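Gem-dimethyl to single methyl on the acid arm

The source may hold more compounds than are shown below. What is called first, only, known or untested is meant among the compounds shown, and "the series" means these compounds.

Compound 2 `CC(C)(C(=O)O)c1nn(Cc2cn3cc(OCC4CC4)c(Cl)cc3n2)c2ccccc2c1=O` gives the lowest number of the three measured in a functional assay on CHO cells for antagonist activity at sphingosine 1-phosphate receptor 2 (Homo sapiens), read by calcium flux (on this read-out lower numbers stand for stronger inhibition and higher numbers for weaker inhibition), at 7.7 nM. Compound 3 `O=C(Cc1nn(CC(=O)N2CCOCC2)c(=O)c2ccccc12)Nc1ccc(OC(F)(F)F)c(Cl)c1` gives 30 nM in this assay, and compound 1 `O=C(Cc1nn(C2CCNC2)c(=O)c2ccccc12)Nc1ccc(OC(F)(F)F)c(Cl)c1` gives 94 nM. Going by the values given here, the only single-point step measured, a 3.1-fold lower number from compound 1 to compound 3 (0.50 log units; beyond the scatter), concerns a substituent on an aromatic nitrogen of a different core and does not bear on the acid arm of compound 2. Compound 4 `C[C@H](C(=O)O)c1nn(Cc2cn3cc(OCC4CC4)c(Cl)cc3n2)c2ccccc2c1=O` differs from compound 2 by 1-carboxyethyl in place of 1-carboxy-1-methylethyl on an aromatic carbon. Among the compounds with values here, no measured step tests a change of this kind, so no shift beyond the scatter is expected in either direction; the estimate for compound 4 is 12 nM (range 4 nM to 40 nM), corresponding to an expected step of a 1.6-fold higher number from compound 2 to compound 4 (0.19 log units; within the scatter).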

Compound 4, half-maximal inhibitory concentration: 3.2 nM
Compound 4: the middle estimate sits 3.8-fold (0.57 log units) above what was measured; the whole stated range lies above it.
By their numbers in this assay, from the lowest: compound 4; then compound 2; then compound 3; then compound 1.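

Going by these compounds alone, on the acid arm, 1-carboxyethyl in place of 1-carboxy-1-methylethyl on the aromatic carbon gives a 2.4-fold lower number from compound 2 to compound 4 (0.38 log units; beyond the scatter) in this assay and this is the first step read at this position. The second methyl is therefore not required for a low number on this core, at least in this single pair, and the entering group brings a defined stereocentre. No measurement at hand accounts for the step.

Open, on these data alone, is how the opposite stereocentre compares, and whether carboxymethyl, with no methyl on the arm, continues the direction. Also open, as far as these compounds go, is how a primary amide or a tetrazole would fare in place of the carboxylic acid.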